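This account rests on a few compounds, and the source may have more. Where it says the series, first, only, none or still open, it means among the compounds named here.

Measured so far, in a physicochemical assay for solubility, in phosphate buffer, at pH 7.4; on this read-out higher numbers stand for higher solubility and lower numbers for lower solubility:
- compound 1 `O=C(NCc1ccccc1)C1=CCCC1C(=O)N1CCCC1`: <= 6000 ug/mL (a limit)
- compound 2 `CC(C)(C)[C@H]1CC[C@@H](C(=O)N2CCCC2)N1C(=O)CCCc1ccccc1`: <= 6000 ug/mL (a limit)

Compound 2 has no exact number on this read-out, as its <= 6000 ug/mL is a limit. The series offers only this picture: the limit of <= 6000 ug/mL in this assay, at which 2 of the 2 values shown sit. For the measured compounds named here, no measured step is available to size a structural change.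

Compound 3 `CC(C)(C)[C@H]1CC[C@@H](C(=O)N2CCCC2)N1C(=O)CCCc1cccnc1` keeps the rest of compound 2 and carries pyridin-3-yl in place of phenyl on a saturated chain carbon, three bonds along the chain from a carbonyl carbon. In this assay, no step beyond the scatter is expected, and no direction is favoured. The expected outcome is a step that the limit leaves unreadable from compound 2 to compound 3. Compound 3 may well report only a limit too. The estimate for compound 3 is 5000 ug/mL, with an expected range of 1500 ug/mL to 6000 ug/mL.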

Compound 3, solubility: <= 6000 ug/mL
Compound 3: a limit, no number; the forecaster's own chance of this, stated with the estimate: 75%; the middle value lies beyond the limit too.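

For the compounds shown here, compound 2 and compound 3 each give only a limit in this assay, so no step between them can be read. The compounds shown leave open where the exact values lie and whether pyridin-3-yl in place of phenyl shifts them at all: the limit of <= 6000 ug/mL in this assay, at which 3 of the 3 values shown sit.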